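Swapping the amine for an azide on a macrocyclic enone

The compounds below may be only part of what the source reports. "The series", "measured", "known", "first", "only" and "open" are said of these compounds alone.

Three macrocyclic esters have been measured in a functional assay on A549 cells (Homo sapiens) for antiproliferative activity, read by MTT assay, with a stated time of 48 h; a higher number here means a weaker inhibitor, a lower number a stronger inhibitor. Compound 1 `COC/C1=C/C[C@](C)(CCC=C(C)C)/C=C/[C@@H](OC(=O)C=C(C)C)[C@](C)(OC)/C=C/C1=O` gives 4180 nM in this assay, while compound 2 `CO[C@]1(C)/C=C/C(=O)/C(CO)=C\C[C@](C)(CCC=C(C)C)/C=C/[C@H]1OC(=O)C=C(C)C` gives 14400 nM. For the measured compounds named here, the only single-point step among them, a 3.4-fold higher number from compound 1 to compound 2 (0.54 log units; beyond the scatter), is a modest weakening. Compound 3 `CC(C)=CCC[C@]1(C)/C=C/[C@@H](OC(=O)C=C(C)C)[C@](C)(O)/C=C/C(=O)/C(CN(C)C)=C\C1` gives 590 nM in this assay, the lowest number of the three and beyond the scatter from both others; it differs from compound 1 and compound 2 in more than one place, so no single step can be read from those gaps.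

Compound 4 `CC(C)=CCC[C@]1(C)/C=C/[C@@H](OC(=O)C=C(C)C)[C@](C)(O)/C=C/C(=O)/C(CN=[N+]=[N-])=C\C1` carries the change (azido in place of dimethylamino on a saturated chain carbon bound to a double-bonded ring carbon). Going by the values given here, no measured step concerns this position or this kind of exchange; the one step that exists, from compound 1 to compound 2, alters an oxygen substituent elsewhere and was modest. The expectation therefore rests on compound 3 alone, with wide uncertainty: a step of a 2.5-fold higher number from compound 3 to compound 4 (0.41 log units; beyond the scatter) is estimated, a mild weakening. Compound 4 is expected to give about 1500 nM in this assay, within roughly 400 nM to 5000 nM.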

Compound 4, half-maximal inhibitory concentration: 1720 nM
Beside the measured number, compound 4's estimate is 1.1-fold (0.06 log units) below it; the range from low to high includes it.
By their numbers in this assay, from the lowest: compound 3; then compound 4; then compound 1; then compound 2.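

In this assay, azido in place of dimethylamino on a saturated chain carbon bound to a double-bonded ring carbon gives a 2.9-fold higher number from compound 3 to compound 4 (0.46 log units; beyond the scatter) and counts as a modest weakening. For the compounds shown here, this is the first step read at this place, and it shows that the dimethylamino group can give way to azido, with the same count of heavy atoms and no net charge on either, at only that modest cost. Nothing available here speaks to why the number moves with this exchange.

Compound 4 differs from compound 1 and from compound 2 in more than one place, so those gaps cannot be read as steps. Still open, from the compounds shown here alone, is where a primary amine or a morpholine on the same carbon would fall relative to dimethylamino and azido.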